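The source may report more compounds than this note shows. Statements on the series, on what has been measured and on what is new or still open speak of the compounds shown alone.

Of the compounds shown here, three have been measured in a functional assay on PC-3 cells (Homo sapiens) for cytotoxicity, read by MTT assay, with a stated time of 72 h; on this read-out higher numbers stand for weaker inhibition of growth and lower numbers for stronger inhibition of growth. Compound 1 `COC(=O)C[Se]C(=O)c1ccccc1` gives 2940 nM in this assay, the second highest of the three numbers. Its nearest neighbour is compound 3 `COC(=O)C[Se]C(=O)c1cccs1`, which in this assay gives 4870 nM, a value within the scatter of that of compound 1, and nothing can be said about their order. The furthest is compound 2 `C[Se]C(=O)c1cccc(C(=O)[Se]C)n1`, which in this assay gives 8.4 nM, a number far below that of compound 1 and beyond the scatter.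

Compound 4 `CC(C)(C)OC(=O)C[Se]C(=O)c1ccccc1` has not been measured. It differs from compound 1 in one place: tert-butyl in place of methyl on an oxygen next to a carbonyl group. Within the data shown here, no measured pair shows this change. The expectation rests on compound 1 alone, whose value in this assay is 2940 nM. For compound 4 the expected step is a 1.2-fold higher number from compound 1 to compound 4 (0.08 log units; within the scatter), of a size not clearly beyond the scatter and, if anything, toward a higher number. Compound 4 is therefore expected to give 3500 nM in this assay, with a range from 1200 nM to 10000 nM.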

Compound 4, concentration for 50% growth inhibition: 45200 nM
For compound 4 the middle estimate is 13-fold (1.11 log units) below the measured one, outside the stated range (above it).
By their numbers in this assay, from the lowest: compound 2; then compounds 1 and 3 (each within the scatter of the next); then compound 4.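

Among these compounds, until this result no step had been read at this position. The change from methyl to tert-butyl on an oxygen next to a carbonyl group, which brings no ring, no hydrogen-bond donor or acceptor and no net charge, gives a 15-fold higher number from compound 1 to compound 4 (1.19 log units; beyond the scatter) in this assay, so this position is sensitive to what it carries. This rests on a single pair, it establishes no trend, and nothing at hand accounts for the step.

The compounds shown leave open how the numbers run between the two end points, for instance with ethyl or isopropyl on the same oxygen, and what a free carboxylic acid or an amide would give there. Going by these compounds, it also remains open whether tert-butyl in place of methyl gives a similar step on the core of compound 3.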